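The compounds below may be only part of what the source reports. "The series", "measured", "known", "first", "only" and "open" are said of these compounds alone.

Measured in a functional assay on A549 cells (Homo sapiens) for antiproliferative activity, read by MTT assay, with a stated time of 72 h; on this read-out lower numbers stand for stronger inhibition and higher numbers for weaker inhibition:
Compound 1 (`O=C(N/N=C/c1cccn1CCCN1CCCC1)Nc1ccc(Oc2ccnc3[nH]ccc23)c(F)c1`): 2010 nM
Compound 2 (`O=C(N/N=C/c1cccn1CCCN1CCCCC1)Nc1ccc(Oc2ccnc3[nH]ccc23)cc1`): 1560 nM

In this assay, compound 2 gives 1560 nM and compound 1 gives 2010 nM. These two values lie within the usual scatter of each other, so compound 2 cannot be placed ahead of compound 1 on these numbers.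

Compound 3 (`O=C(N/N=C/c1cccn1CCCN1CCCC1)Nc1ccc(Oc2ccnc3[nH]ccc23)cc1`) has not yet been measured. It differs from compound 2 in one place: pyrrolidin-1-yl in place of piperidin-1-yl on a saturated chain carbon, three bonds along the chain from an aromatic nitrogen. In words, pyrrolidin-1-yl stands in place of piperidin-1-yl on a saturated chain carbon, three bonds along the chain from an aromatic nitrogen.

Going by the values given here, no measured pair shows this change on its own, so its size in this assay has no direct precedent. Compound 1 also carries 3-(pyrrolidin-1-yl)propyl and gives 2010 nM, which offers only a loose guide, as it is not otherwise identical to compound 3. No step beyond the scatter is expected in either direction. The expected change is a 1.1-fold higher number from compound 2 to compound 3 (0.04 log units; within the scatter). For compound 3 the estimated value is 1700 nM, with an expected range from 750 nM to 3800 nM.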

Compound 3, half-maximal inhibitory concentration: 1300 nM
For compound 3 the middle estimate is 1.3-fold (0.12 log units) above the measured one, within the range that was stated.
By their numbers in this assay, from the lowest: compounds 3, 2 and 1 (each within the scatter of the next).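

In this assay, pyrrolidin-1-yl in place of piperidin-1-yl on a saturated chain carbon, three bonds along the chain from an aromatic nitrogen, now has a direct reading: a 1.2-fold lower number from compound 2 to compound 3 (0.08 log units; within the scatter). Compound 3 also gives a reading of hydrogen in place of fluoro on an aromatic carbon, a 1.5-fold lower number from compound 1 to compound 3 (0.19 log units; within the scatter), so on these numbers neither the two saturated rings nor the hydrogen and the fluoro can be told apart. No other measurement bears on these results, and nothing shown accounts for them.

The compounds shown leave open whether a saturated ring of a different kind at the end of the chain, such as morpholin-4-yl or 4-methylpiperazin-1-yl, or an open dimethylamino group, or a different length of chain such as 2-(pyrrolidin-1-yl)ethyl, would give a step beyond the scatter. They also leave open whether chloro or methoxy on that aromatic carbon would separate from the hydrogen and the fluoro in this assay.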